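Hydroxybutyl for Phenyl on Two Related Cores

The compounds below may be only part of what the source reports. "The series", "measured", "known", "first", "only" and "open" are said of these compounds alone.

Compound 1 `CSc1nc(NCCCCCO)c2cccnc2n1`, in a functional assay on MCF7 cells (Homo sapiens) for cytotoxicity, read by MTT assay, with a stated time of 72 h (a lower number here means a stronger inhibitor of growth, a higher number a weaker inhibitor of growth), reaches only the limit of > 100000 nM.
Compound 2 `CSc1nc(NCc2ccccc2)c2ccccc2n1` gives 82800 nM in this assay.
Compound 3 `CSc1nc(NCc2ccccc2)c2cccnc2n1` reaches only the limit of > 100000 nM in this assay.

Among the measured compounds shown here, compound 2 is the single compound with a number; the other two sit at a limit, see (the limit of > 100000 nM in this assay, at which 2 of the 3 values shown sit). From compound 3 to compound 1 the change 4-hydroxybutyl in place of phenyl on a saturated chain carbon bound to a nitrogen on an aromatic ring gives a step that the two limits leave unreadable from compound 3 to compound 1. The difference between the cores of compound 2 and compound 3 is not broken down here. Compound 4 `CSc1nc(NCCCCCO)c2ccccc2n1` is unmeasured and carries the same kind of change from compound 2, (4-hydroxybutyl in place of phenyl on a saturated chain carbon bound to a nitrogen on an aromatic ring). Since compound 3 already sits at the limit, that earlier step shows only that the hydroxybutyl form did not leave the limit, (the limit of > 100000 nM in this assay, at which 2 of the 3 values shown sit). Compound 4 is estimated at 150000 nM, within 50000 nM to 500000 nM. The expected step is a 1.8-fold higher number from compound 2 to compound 4 (0.26 log units; within the scatter), resting on compound 2 at 82800 nM and on the unreadable earlier step.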

Compound 4, concentration for total growth inhibition: > 100000 nM
Compound 4 ended at the assay's limit; the forecaster's own chance of this, stated with the estimate: 65%; the middle value does not contradict the limit.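

In this assay, carrying 4-hydroxybutyl in place of phenyl onto the core of compound 2 gives an at least 1.2-fold higher number from compound 2 to compound 4 (0.08 log units; that floor lies within the scatter), a floor within the scatter and no measured size, so it does not show that the change weakens growth inhibition: the limit of > 100000 nM in this assay, at which 3 of the 4 values shown sit.

Compound 4 gives > 100000 nM, which is a limit of the assay.

The change leaves a limit on both cores, but the steps between two limits cannot be read, so the data do not show whether its size is the same on the two cores.

The compounds shown leave open whether an amine, a carboxylic acid or a longer chain in place of 4-hydroxybutyl would give a readable number in this assay on either core.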